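The compounds below may be only part of what the source reports. "The series", "measured", "known", "first", "only" and "open" are said of these compounds alone.

Measured compounds:
- compound 1 `NC(=O)c1c(NC(=O)c2ccccc2F)sc2c1CCN(Cc1c(Cl)cccc1Cl)C2`: 33000 nM
- compound 2 `NC(=O)c1c(NC(=O)c2ccccc2F)sc2c1CCN(Cc1ccc(Cl)cc1Cl)C2`: 27500 nM
- compound 3 `NC(=O)c1c(NC(=O)c2ccccc2F)sc2c1CCN(C(=S)Nc1ccccc1Cl)C2`: 19400 nM

All three numbers come from a functional assay on HeLa cells (Homo sapiens) for antiproliferative activity, with a stated time of 24 h; a lower number here means a stronger inhibitor, a higher number a weaker inhibitor. The three values sit close together: a 1.2-fold lower number from compound 1 to compound 2 (0.08 log units; within the scatter), a 1.7-fold lower number from compound 1 to compound 3 (0.23 log units; within the scatter) and a 1.4-fold lower number from compound 2 to compound 3 (0.15 log units; within the scatter) all fall within the usual scatter, so compound 3 cannot be set apart from compound 1 or compound 2 on these numbers. Every measured step concerns only the group on the amine nitrogen in the ring.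

Compound 4 `NC(=O)c1c(NC(=O)c2ccc(C(F)(F)F)cc2)sc2c1CCN(C(=S)Nc1ccccc1Cl)C2` differs from compound 3 elsewhere: 4-(trifluoromethyl)phenyl in place of 2-fluorophenyl on a carbonyl carbon. Among the compounds with values here, no measured step touches this part of the molecule, so the data give no guide to the direction of any change, and the shared core with the thiourea side group has so far given only weak inhibition. The step in this assay is expected to be a 1.0-fold higher number from compound 3 to compound 4 (0.01 log units; within the scatter), with wide uncertainty. Compound 4 is therefore estimated at 20000 nM, with a range from 5000 nM to 80000 nM.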

Compound 4, half-maximal inhibitory concentration: 44000 nM
Compound 4: middle estimate off by 2.2-fold (0.34 log units), on the low side; the measured number falls inside the stated range.
By their numbers in this assay, from the lowest: compounds 3, 2, 1 and 4 (each within the scatter of the next, the first and the last beyond it).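

The earlier compounds shown here varied only the group on the amine nitrogen in the ring, and none of those steps went beyond the scatter. Here, a change on the carbonyl carbon in this assay gives a 2.3-fold higher number from compound 3 to compound 4 (0.36 log units; beyond the scatter), a modest but real loss of inhibition, so this is the first position shown where a single change separates two compounds. Both the fluorine count and the group's name change at once, so the step cannot be tied to one feature, and no measured evidence accounts for it.

Going by these compounds, it remains open whether plain phenyl or 4-fluorophenyl on this carbonyl carbon would keep the number of compound 3. On these data alone, it is also open whether the same swap would act alike in compound 1 or compound 2, which carry dichlorophenyl groups on the nitrogen side.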